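The source may report more compounds than this note shows. Statements on the series, on what has been measured and on what is new or still open speak of the compounds shown alone.

The account opens with three measured compounds. In a functional assay on IMR-32 cells with melanin-concentrating hormone receptor 1 (Homo sapiens) as the target, read by fluorescence (on this read-out lower numbers stand for stronger inhibition and higher numbers for weaker inhibition), compound 1 `CC1CCCCC1Oc1cccc2ccc(N)nc12` gives 1330 nM and compound 3 `CCCC(C)Oc1cccc2ccc(N)nc12` gives 860 nM, two values that lie within the usual scatter of each other. Compound 2 `CC(CC(C)(C)C)Oc1cccc2cccnc12` carries no nitrogen group on its core. In this assay compound 2 gives only > 10000 nM, which is a limit of the assay and not a number (the limit of > 10000 nM in this assay, at which 1 of the 3 values shown sits). Compound 2 is thus the one of the three that sits at the limit rather than at a measured value. The step to compound 4 `CC(CC(C)(C)C)Oc1cccc2ccc(N(C)C)nc12` is dimethylamino in place of hydrogen on an aromatic carbon. Going by the values given here, no measured pair differs in that one place alone, so the size of the step is not known from the data; compound 1 and compound 3, which bear an amino group on their cores, give values well inside the measurable range. The account expects compound 4 to gain potency beyond the scatter, with an at least 6.6-fold lower number from compound 2 to compound 4 (0.82 log units; beyond the scatter) as the estimated step. Compound 4 is expected at 1500 nM, between 400 nM and 6000 nM.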

Compound 4, half-maximal inhibitory concentration: > 10000 nM
Compound 4: no number, only a limit; the forecaster's own chance of this, stated with the estimate: 15%; at least 6.6-fold (0.82 log units) between middle value and limit.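

No step can be read from compound 2 to compound 4, because each stands at a limit of the assay and not at a number: the limit of > 10000 nM in this assay, at which 2 of the 4 values shown sit.

The compounds shown leave open how large a change, if any, dimethylamino in place of hydrogen brings in this assay on this core.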